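The compounds below may be only part of what the source reports. "The series", "measured", "known", "first", "only" and "open" are said of these compounds alone.

Measured in a functional assay on ACHN cells (Homo sapiens) for inhibition, read by sulforhodamine B assay, with a stated time of 48 h, tested at 1 uM; a lower number here means a stronger effect, a higher number a weaker effect of the compound at the concentration tested:
compound 1 `O=C(Nc1cccc(-n2cc(-c3ccncc3)c(-c3cc(O)cc(Cl)c3)n2)c1)Nc1ccc(Cl)c(C(F)(F)F)c1`: 92%
compound 2 `COc1cc(Cl)cc(-c2nn(-c3cccc(NC(=O)Nc4ccc(Cl)c(C(F)(F)F)c4)c3)cc2-c2ccncc2)c1`: 45%
compound 3 `COc1cc(Cl)cc(-c2nn(-c3cccc(NC(=O)Nc4cc(C(F)(F)F)cc(C(F)(F)F)c4)c3)cc2-c2ccncc2)c1`: 17%

Compound 2 stands second highest of the three numbers, between compound 3 and compound 1. Going by the values given here, the single one-place step measured, a number 47 percentage points lower from compound 1 to compound 2 (beyond the scatter), concerns the oxygen on the aromatic ring and does not bear on the change now considered. Compound 4 `COc1cc(Cl)cc(-c2nn(-c3cccc(NC(=O)c4cccc(C(F)(F)F)c4)c3)cc2-c2ccncc2)c1` differs from compound 2 by 3-(trifluoromethyl)phenyl in place of (4-chloro-3-(trifluoromethyl)phenyl)amino on a carbonyl carbon. Compounds 2 and 3 keep the amino group on the carbonyl carbon and differ in the aromatic ring it bears; their values show that this part of the molecule moves the number beyond the scatter. Among the compounds with values here, no measured compound lacks that amino group, so the direction rests on no step. In this assay compound 4 is expected to give 65% (range 35% to 95%), an estimated step of a number 20 percentage points higher from compound 2 to compound 4 (beyond the scatter) upward and uncertain.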

Compound 4, a percentage reported as activity, at one concentration (the size of the read-out at that concentration, not a potency): 54%
For compound 4 the middle estimate is 11 percentage points above the measured one; measured number inside the range.
By their numbers in this assay, from the lowest: compound 3; then compounds 2 and 4 (each within the scatter of the next); then compound 1.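

In this assay, the step of a number 9 percentage points higher from compound 2 to compound 4 (within the scatter) shows that the amino group on the carbonyl carbon is not needed to keep the read-out of this pair at the tested concentration. The change also removes the chlorine, so this pair cannot separate the two losses. No data here bear on the reason for this result.

Open, from the compounds shown here alone, is how the aromatic ring of compound 3 behaves on that carbonyl carbon without the amino group. Also open, going by these compounds, is how a methylene in place of that amino group would read.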